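The source may hold more compounds than are shown below. What is called first, only, known or untested is meant among the compounds shown, and "the series" means these compounds.

Compound 1 `C[C@@H]1CN(C(=O)OC(C)(C)C)CCN1c1ncc(OCc2ccc(S(=O)(=O)N(C)C)cc2)cn1` and compound 2 `C[C@@H]1CN(C(=O)OC(C)(C)C)CCN1c1ncc(OCc2ccc(C#N)cc2)cn1` share a core and differ in one place. In a physicochemical assay for lipophilicity, using the shake flask method, in phosphate buffer, measured as octanol-water partition, at pH 7.4 (on this read-out lower numbers stand for lower lipophilicity and higher numbers for higher lipophilicity), compound 1 gives > 4.3, which is a limit and not a number. In this assay, compound 2 gives > 3.6, and this is also a limit. Among the compounds with values here, compound 2 therefore has no exact position, and the only other value beside it is a limit too.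

The next compound, still unmeasured, is compound 3 `C[C@@H]1CN(C(=O)OC(C)(C)C)CCN1c1ncc(OCc2ccc(S(C)(=O)=O)cc2F)cn1`. The change is 2-fluoro-4-(methylsulfonyl)phenyl in place of 4-cyanophenyl on a saturated chain carbon bound to an oxygen on an aromatic ring.

Within the data shown here, only one measured step bears on this change: a step that the two limits leave unreadable from compound 1 to compound 2. Its size cannot be read, so it offers neither a size nor a direction to carry over. No step beyond the usual scatter is therefore expected in this assay. The expected change is a step that the limit leaves unreadable from compound 2 to compound 3. Compound 3 is estimated at 3.8, with an expected range from 3.2 to 4.4.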

Compound 3, distribution coefficient: 3.7
Beside the measured number, compound 3's estimate is 0.10 log units above it; the measured number falls inside the stated range.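

In this assay no step can be read from compound 2 to compound 3, because compound 2 is known only through a limit and not a number: the limit of > 3.6 in this assay, at which 1 of the 3 values shown sits. The compounds shown leave open where compound 1 and compound 2 exactly stand, and with that the size and direction of both changes in the series.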